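A Pyrrolidine Amide Replaces the Cyclohexyl Group of Compound 1

The source may report more compounds than this note shows. Statements on the series, on what has been measured and on what is new or still open speak of the compounds shown alone.

Compound 1 `CC1CCCN1C1CCN(c2ccc(NC(=O)NC3CCCCC3)cc2)C1` was tested in an assay on CHO cells for displacement of a labelled ligand from histamine receptor H3 (Macaca mulatta), read by scintillation counting, with a stated time of 1 h (on this read-out higher numbers stand for weaker inhibition and lower numbers for stronger inhibition), and gives 4.1 nM. Among the three compounds measured, this is the lowest number. Compound 2 `Cc1cc(N2CCC(N3CCCC3C)C2)ccc1NC(=O)NC1CCCCC1` gives 4.6 nM, and the step of a 1.1-fold higher number from compound 1 to compound 2 (0.05 log units; within the scatter) shows that compound 1 and compound 2 cannot be told apart. Compound 3 `Cc1cc(NC(=O)NC2CCCCC2)ccc1N1CCC(N2CCCC2C)C1` gives 11.2 nM, and the step of a 2.7-fold higher number from compound 1 to compound 3 (0.44 log units; beyond the scatter) is a modest weakening.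

Compound 4 `CC(=O)N(C)C1CCN(C(=O)Nc2ccc(N3CCC(N4CCCC4C)C3)cc2)C1` has not yet been measured in this assay. It differs from compound 1 in one place: 3-(acetyl(methyl)amino)pyrrolidin-1-yl in place of cyclohexylamino on a carbonyl carbon. Both measured steps concern a methyl in place of hydrogen on an aromatic carbon, and the shared core is left unchanged in each; neither step touches the carbonyl carbon where compound 4 differs, so neither bears directly on this change. The two measured steps show that small changes elsewhere cost little or only a modest amount. With nothing measured for the exchange of cyclohexylamino for 3-(acetyl(methyl)amino)pyrrolidin-1-yl, the expectation is uncertain, and a somewhat weaker result is estimated, namely a step of a 3.7-fold higher number from compound 1 to compound 4 (0.56 log units; beyond the scatter). For compound 4 the estimate in this assay is 15 nM, with a range from 3 nM to 80 nM.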

Compound 4, inhibition constant: 35.5 nM
Compound 4: middle estimate off by 2.4-fold (0.37 log units), on the low side, within the range that was stated.
By their numbers in this assay, from the lowest: compounds 1 and 2 (each within the scatter of the next); then compound 3; then compound 4.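

In this assay, within the data shown here, this is the first change at the carbonyl carbon rather than on an aromatic carbon, and it gives an 8.7-fold higher number from compound 1 to compound 4 (0.94 log units; beyond the scatter), a larger step than the largest methyl step, a 2.7-fold higher number from compound 1 to compound 3 (0.44 log units; beyond the scatter). The group on this carbonyl carbon therefore affects the measured number more than either methyl change does, although the step is still modest and the exchange does not abolish inhibition. Several things change together here: a six-membered ring of carbon only gives way to a five-membered ring with 1 hetero atom, the number of heavy atoms rises, and the hydrogen-bond donor of cyclohexylamino gives way to the hydrogen-bond acceptor of the new group, and nothing available explains the weakening or ties it to any one of these differences.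

From the compounds shown here alone, it remains open whether the step follows from the loss of cyclohexylamino, from the change of ring, or from the acetyl(methyl)amino part of the entering group. A plain pyrrolidin-1-yl group or a cyclopentylamino group on the same carbonyl carbon would help to separate these possibilities, and adding either methyl change to compound 4 would show whether the two kinds of change act independently.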